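One methyl added to compound 2

The source may hold more compounds than are shown below. What is called first, only, known or untested is meant among the compounds shown, and "the series" means these compounds.

In a functional assay on DU-145 cells (Homo sapiens) for inhibition, read by CCK-8 assay, with a stated time of 72 h (on this read-out higher numbers stand for weaker inhibition and lower numbers for stronger inhibition), compound 1 `O=C(/C=C/c1cccnc1)NCCCc1ccc(S(=O)(=O)Nc2ccccc2)cc1` gives only a limit, > 10000 nM. Among the measured compounds shown here, compound 2 `O=C(/C=C/c1cccnc1)NCCCCCCc1cccc(S(=O)(=O)Nc2ccccc2)c1` gives 6.73 nM, the only actual number so far. Compound 3 `Cc1cccc(NS(=O)(=O)c2cccc(CCCCCCNC(=O)/C=C/c3cccnc3)c2)c1` departs from compound 2 by a single change, methyl in place of hydrogen on an aromatic carbon, which turns phenylsulfamoyl into (3-methylphenyl)sulfamoyl. For the measured compounds named here, no measured pair yet shows what such a change does in this assay. The expectation therefore starts from compound 2 at 6.73 nM and allows for a small shift towards weaker inhibition, possibly none beyond the usual scatter. The expected step is a 1.5-fold higher number from compound 2 to compound 3 (0.17 log units; within the scatter). For compound 3, the estimated value is 10 nM, within an expected range of 3 nM to 40 nM.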

Compound 3, half-maximal inhibitory concentration: 41.7 nM
Beside the measured number, compound 3's estimate is 4.2-fold (0.62 log units) below it, outside the stated range (above it).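

In this assay, among the compounds shown here, the change from phenylsulfamoyl to (3-methylphenyl)sulfamoyl gives a 6.2-fold higher number from compound 2 to compound 3 (0.79 log units; beyond the scatter) and is the first step between two measured compounds. It shows that this aromatic carbon is sensitive to substitution: a methyl of a single heavy atom, with no ring, no charge and no hydrogen-bond donors or acceptors, moves the number beyond the usual scatter towards weaker inhibition, while compound 3 still gives a measured value rather than a limit. The compounds shown offer nothing that accounts for this step.

From the compounds shown here alone, whether a fluorine, a chlorine or a methoxy group at this carbon would give a step of similar size remains open. So does whether a methyl elsewhere on the same ring would behave like this one.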